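The source may hold more compounds than are shown below. What is called first, only, known or untested is meant among the compounds shown, and "the series" means these compounds.

Measured so far:

Compound 1, `CC[C@H](C)[C@H](N)CN(C(=O)[C@@H]1C[C@H]1C1CCCCC1)c1ccc(-c2ccccc2)cc1`: in a functional assay for agonist activity at G protein-coupled receptor 88 (Homo sapiens), read by HTRF and cAMP accumulation (a lower number here means that less compound is needed, a higher number that more compound is needed for the effect), compound 1 gives > 25000 nM, which is a limit of the assay and not a number.
Compound 2, `CC[C@H](C)[C@H](N)CN(C(=O)[C@@H]1C[C@H]1c1nccs1)c1ccc(-c2ccccc2)cc1`: in this assay compound 2 gives 210 nM.
Compound 3, `CC[C@H](C)[C@H](N)CN(C(=O)[C@@H]1C[C@H]1c1ccsc1)c1ccc(-c2ccccc2)cc1`: in this assay compound 3 gives 450 nM.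

Of the two compounds with a number, compound 3 has the higher one; its nearest neighbour is compound 2, and the step reads a 2.1-fold higher number from compound 2 to compound 3 (0.33 log units; beyond the scatter). Compound 1 sits at a limit (the limit of > 25000 nM in this assay, at which 1 of the 3 values shown sits).

The step under discussion leads to compound 4, `CC[C@H](C)[C@H](N)CN(C(=O)[C@@H]1C[C@H]1c1nc(C)c(C)s1)c1ccc(-c2ccccc2)cc1`. The change is 4,5-dimethyl-1,3-thiazol-2-yl in place of thiophen-3-yl on a saturated ring carbon.

Going by the values given here, three measured steps bear on this position. Replacing the saturated cyclohexyl by an aromatic ring gave an at least 110-fold lower number from compound 1 to compound 2 (2.07 log units; beyond the scatter) and an at least 55-fold lower number from compound 1 to compound 3 (1.74 log units; beyond the scatter), both large. Between the two aromatic rings the difference was modest: a 2.1-fold higher number from compound 2 to compound 3 (0.33 log units; beyond the scatter). Among the compounds with values here, compound 4 carries the same 1,3-thiazol-2-yl ring as compound 2, now with two added methyl groups, for which no measured step exists. A modest move toward the number of compound 2 is therefore the expectation, with added uncertainty for the methyl groups: a 1.8-fold lower number from compound 3 to compound 4 (0.26 log units; within the scatter).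

For compound 4 the estimate in this assay is 250 nM, expected to fall between 80 nM and 800 nM.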

Compound 4, half-maximal effective concentration: 3600 nM
For compound 4 the middle estimate is 14-fold (1.16 log units) below the measured one; measured number above the stated range.
By their numbers in this assay, from the lowest: compound 2; then compound 3; then compound 4. At a limit, above all of these: compound 1.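

In this assay, adding the two methyl groups to the 1,3-thiazol-2-yl ring matters far more than exchanging one aromatic ring for the other did, with a 17-fold higher number from compound 2 to compound 4 (1.23 log units; beyond the scatter), and this is the only step shown that changes nothing but those methyl groups. Against the thiophen-3-yl ring the change reads an 8.0-fold higher number from compound 3 to compound 4 (0.90 log units; beyond the scatter), so an aromatic ring on this saturated ring carbon does not by itself keep the number low, and what that ring carries counts as well. Part of the gain over cyclohexyl survives, with an at least 6.9-fold lower number from compound 1 to compound 4 (0.84 log units; beyond the scatter), but this step is only a bound, as its starting value is a limit and not a number: the limit of > 25000 nM in this assay, at which 1 of the 4 values shown sits.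

From the compounds shown here alone, it remains open whether a single methyl group, as in 4-methyl-1,3-thiazol-2-yl or 5-methyl-1,3-thiazol-2-yl, would account for most of the rise or whether both are needed for it. Also open, going by these compounds, is how other groups on that ring, such as an amine or a carboxylic acid, or a plain phenyl ring on the saturated ring carbon, would read in this assay.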